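Replacing the imidazole of compound 2 with dimethylamino

The source may hold more compounds than are shown below. What is called first, only, known or untested is meant among the compounds shown, and "the series" means these compounds.

Compound 1 `CCOC(=O)N(C)CC#CCn1cncc1C`: 66 mg/kg
Compound 2 `O=C1NCCN1CC#CCn1ccnc1`: > 100 mg/kg
Compound 3 `Cc1cncn1CC#CCN1CCNC1=O`: 21 mg/kg
Compound 4 `CN(C)CC#CCN1CCNC1=O`: not yet measured

In a functional assay on the whole organism for antagonist activity, with Mus musculus as the target (on this read-out lower numbers stand for an effect already at smaller amounts and higher numbers for an effect only at larger amounts of compound), compound 2 stands at the limit of > 100 mg/kg in this assay, at which 1 of the 3 values shown sits, and this is a limit, not a number. The change to compound 4 is dimethylamino in place of 1H-imidazol-1-yl on a saturated chain carbon bound to a triple-bonded carbon and consists of dimethylamino in place of 1H-imidazol-1-yl on a saturated chain carbon bound to a triple-bonded carbon. Going by the values given here, one measured step bears on it, an at least 4.7-fold lower number from compound 2 to compound 3 (0.67 log units; beyond the scatter), and it alters the same 1H-imidazol-1-yl group that now leaves. Among the compounds with values here, that step shows that this assay can respond to a change at this group, but no measured step replaces the group outright, so the guide is weak. A modest move toward a lower number is therefore expected, namely an at least 2.0-fold lower number from compound 2 to compound 4 (0.30 log units; that floor lies within the scatter), and a further limit would be no surprise. For compound 4 the estimated value is 50 mg/kg with an expected range from 12 mg/kg to 200 mg/kg.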

Compound 4, dose for half-maximal effect: > 100 mg/kg
Compound 4: only a limit was reported; the forecaster's own chance of this, stated with the estimate: 40%; middle value at least 2.0-fold (0.30 log units) away from the limit.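

In this assay compound 2 gives > 100 mg/kg, which is a limit. Compound 4 gives > 100 mg/kg, also a limit, so the step from compound 2 to compound 4 cannot be read: the limit of > 100 mg/kg in this assay, at which 2 of the 4 values shown sit.

The compounds shown leave open whether dimethylamino in place of 1H-imidazol-1-yl shifts the read-out of this assay at all.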